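Ethyl on the piperidine nitrogen of compound 3

The compounds below may be only part of what the source reports. "The series", "measured", "known", "first", "only" and "open" are said of these compounds alone.

Measured so far in an assay on HeLa cells for displacement of a labelled ligand from 5-hydroxytryptamine receptor 6 (Homo sapiens); on this read-out lower numbers stand for stronger inhibition and higher numbers for weaker inhibition:
- compound 1 `CN1CCC(n2cc(S(=O)(=O)c3cccc(F)c3)c3cccnc32)C1` gives 1.4 nM
- compound 2 `CCN1CCCC(n2cc(S(=O)(=O)c3ccc(Cl)cc3)c3cccnc32)C1` gives 33.5 nM
- compound 3 `O=S(=O)(c1cccc(F)c1)c1cn(C2CCCNC2)c2ncccc12` gives 2.4 nM

Compound 3 holds the second highest of the three numbers; its nearest neighbour is compound 1, and the step of a 1.7-fold higher number from compound 1 to compound 3 (0.23 log units; within the scatter) lies within the scatter, while compound 2 stands far beyond it. Compound 4 `CCN1CCCC(n2cc(S(=O)(=O)c3cccc(F)c3)c3cccnc32)C1` differs from compound 3 by ethyl in place of hydrogen on an amine nitrogen in a ring. Going by the values given here, no measured step covers this change. Compound 2 carries the same 1-ethylpiperidin-3-yl group yet differs from compound 4 elsewhere, so its higher number only hints that an ethyl here may not help. A modest rise in this assay is therefore expected, a 1.9-fold higher number from compound 3 to compound 4 (0.27 log units; within the scatter), and compound 4 is estimated at 4.5 nM, between 1.5 nM and 15 nM.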

Compound 4, inhibition constant: 4.4 nM
Compound 4: the middle estimate sits 1.0-fold (0.01 log units) above what was measured; the range from low to high includes it.
By their numbers in this assay, from the lowest: compounds 1, 3 and 4 (each within the scatter of the next, the first and the last beyond it); then compound 2.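

In this assay, ethyl on the piperidine nitrogen gives a 1.8-fold higher number from compound 3 to compound 4 (0.26 log units; within the scatter) and so is tolerated at this position. Two steps lie beyond the scatter: 3-fluorophenyl in place of 4-chlorophenyl on the sulfonyl sulfur gives a 7.6-fold lower number from compound 2 to compound 4 (0.88 log units; beyond the scatter) with the 1-ethylpiperidin-3-yl group held constant, and 1-ethylpiperidin-3-yl in place of 1-methylpyrrolidin-3-yl gives a 3.1-fold higher number from compound 1 to compound 4 (0.50 log units; beyond the scatter) with the 3-fluorophenyl group held constant. No measurement here explains the size of any of these steps.

The compounds shown leave open whether a longer chain on this nitrogen, such as butyl or benzyl, would still be tolerated. They also leave open what a carboxylic acid at the end of such a chain would do.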